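The source may report more compounds than this note shows. Statements on the series, on what has been measured and on what is new or still open speak of the compounds shown alone.

The study concerns a small set of pyrrole carboxylic acids tested in an assay on cells for inhibition of Palmitoleoyl-protein carboxylesterase NOTUM variant C330S (Homo sapiens), read by fluorescence, with a stated time of 40 min; on this read-out higher numbers stand for weaker inhibition and lower numbers for stronger inhibition. Compound 1, `Cc1[nH]c(C(F)(F)F)cc1C(=O)O`, gives 6700 nM in this assay. Compound 2, `Cc1cc(C(=O)O)c(C)n1CC1CC1`, gives 12700 nM. Compound 3, `Cc1cc(C(=O)O)c[nH]1`, gives 100000 nM, the highest of the three numbers; the nearest to it is compound 2 and the furthest is compound 1, and both gaps lie beyond the scatter of repeated measurements, so compound 3 stands as the weakest inhibitor among the measured compounds.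

The step followed here leads from compound 3 to compound 4, `Cc1cc(C(=O)O)c(C)[nH]1`, which has not yet been measured. The change is methyl in place of hydrogen on an aromatic carbon. Within the data shown here, no measured pair shows this single change on its own; compound 2 carries the same methyl but also bears a substituent on the ring nitrogen, so its value can only hint at the direction.

Since compound 3 sits at the weak end and compound 2, which contains the added methyl, gives 12700 nM, the step from compound 3 to compound 4 is expected to bring a moderate gain in inhibition, a 3.3-fold lower number from compound 3 to compound 4 (0.52 log units; beyond the scatter), though a step within the scatter cannot be excluded. Compound 4 is therefore estimated at 30000 nM, with a range from 10000 nM to 100000 nM.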

Compound 4, half-maximal inhibitory concentration: > 100000 nM
Compound 4 gave a limit, no number; the forecaster's own chance of this, stated with the estimate: 25%; at least 3.3-fold (0.52 log units) between middle value and limit.
By their numbers in this assay, from the lowest: compounds 1 and 2 (each within the scatter of the next); then compound 3.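

In this assay compound 4 gives > 100000 nM, which is a limit of the assay and not a number. The methyl on an aromatic carbon, next to the ring nitrogen and next to the ring atom that bears a carboxy group, gives a number no lower from compound 3 to compound 4 (the limit leaves the size open), so it brings no visible gain, although the size of that step cannot be read. Against compound 4, hydrogen in place of cyclopropylmethyl on an aromatic nitrogen gives an at least 7.8-fold higher number from compound 2 to compound 4 (0.89 log units; beyond the scatter), and methyl in place of trifluoromethyl on an aromatic carbon gives an at least 14-fold higher number from compound 1 to compound 4 (1.17 log units; beyond the scatter), so the lower numbers of compounds 1 and 2 go with the cyclopropylmethyl and trifluoromethyl groups and not with this methyl alone.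

The compounds shown leave open whether this methyl weakens inhibition relative to compound 3 or leaves it unchanged. They also leave open how other groups would fare, such as a longer chain or an amine on the aromatic nitrogen, or a nitrile in place of the trifluoromethyl on the aromatic carbon.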